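The compounds below may be only part of what the source reports. "The series", "measured", "known", "first", "only" and "open" are said of these compounds alone.

Of the compounds shown here, two have been tested in a functional assay on the whole organism for inhibition, with Rattus norvegicus as the target; a higher number here means that more compound is needed for the effect, a lower number that less compound is needed. Compound 1, `CC1CC/C(=N\Nc2ccccc2)c2nccc(=O)n21`, gives in this assay > 100 umol/kg, which is a limit of the measurement rather than a number (the limit of > 100 umol/kg in this assay, at which 1 of the 2 values shown sits). Compound 2, `CC1CC/C(=N\Nc2ccccc2Cl)c2ncc(C(=O)O)c(=O)n21`, gives in this assay > 1000 umol/kg, again a limit rather than a number (the limit of > 1000 umol/kg in this assay, at which 1 of the 2 values shown sits). Compound 2 therefore stands at the edge of what this assay can report, with no exact figure known for it. Compound 3, `Cc1ccc(N/N=C2\CCC(C)n3c2ncc(C(=O)O)c3=O)cc1`, is the next compound to be measured. It differs from compound 2 in one place: 4-methylphenyl in place of 2-chlorophenyl on an amine nitrogen. Going by the values given here, no measured step exists to guide the expectation; both tested compounds sit at a limit. The step of a number no higher from compound 2 to compound 3 (the limit leaves the size open) is expected to be small, with no clear direction beyond the usual scatter. For compound 3 the estimate in this assay is 1000 umol/kg, with a range from 300 umol/kg to 3000 umol/kg, and it is expected that the assay will once more report only a limit rather than a number.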

Compound 3, dose for 50% inhibition: > 1000 umol/kg
Compound 3: a limit, no number; the forecaster's own chance of this, stated with the estimate: 80%; the middle value sits exactly at the limit.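

In this assay compound 3 gives > 1000 umol/kg, which is a limit and not a number. Compound 2 also stands at a limit, so no step can be read between compound 2 and compound 3. The compounds shown leave open how much of any of them is actually needed for the effect, and whether swapping 2-chlorophenyl for 4-methylphenyl changes that amount.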